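Shortening the phenoxyalkenyl chain on the EP3 agonist core

The source may report more compounds than this note shows. Statements on the series, on what has been measured and on what is new or still open speak of the compounds shown alone.

Among the compounds with values here, compound 1 `O=C(O)c1csc([C@H]2CC[C@@H]3[C@@H](/C=C/CCCOc4ccccc4)[C@H](O)C[C@@H]3O2)n1` is the one member of this set with a numbered result in a functional assay on CHO cells for agonist activity at prostaglandin E2 receptor EP3 subtype (Homo sapiens), read by fluorescence and calcium flux; a lower number here means that less compound is needed, a higher number that more compound is needed for the effect. In this assay compound 1 gives 360 nM. Compound 2 `O=C(O)c1csc([C@H]2CC[C@@H]3[C@@H](COc4ccccc4)[C@H](O)C[C@@H]3O2)n1` is the other member. In this assay, within the data shown here, compound 2 reaches only > 10000 nM, which is a limit of the assay and not a number; this is the limit of > 10000 nM in this assay, at which 1 of the 2 values shown sits, so compound 1 is the only compound with a measured position to stand on.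

Compound 3 `O=C(O)c1csc([C@H]2CC[C@@H]3[C@@H](/C=C/CCOc4ccccc4)[C@H](O)C[C@@H]3O2)n1` is not yet measured. It differs from compound 1 by phenoxy in place of phenoxymethyl on a saturated chain carbon, two bonds along the chain from a double-bonded chain carbon. Among the measured compounds shown here, no step between measured compounds of this kind exists here, so the expectation rests on compound 1 alone and on the fact that compound 2 sits at the limit. The estimated step is a 3.3-fold higher number from compound 1 to compound 3 (0.52 log units; beyond the scatter), toward a higher number that stays far short of the limit. Compound 3 is therefore estimated at 1200 nM, within a range from 400 nM to 5000 nM.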

Compound 3, half-maximal effective concentration: 260 nM
Compound 3: middle estimate off by 4.6-fold (0.66 log units), on the high side; the whole stated range lies above it.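

The change at this place, phenoxy in place of phenoxymethyl on a saturated chain carbon, two bonds along the chain from a double-bonded chain carbon, gives a 1.4-fold lower number from compound 1 to compound 3 (0.14 log units; within the scatter) in this assay. The chain of compound 1 can therefore be shortened at this point without any change that can be told from the scatter, so the two compounds stand level and neither can be ranked over the other. Compound 2 differs from compound 3 in more than one place, so this step does not reach it, and its result remains a limit of the assay and not a number: the limit of > 10000 nM in this assay, at which 1 of the 3 values shown sits.

The compounds shown leave open how far the chain can be changed in either direction, whether with a longer chain than that of compound 1 or with a shortened chain that still keeps the double bond. They also do not tell whether the ether oxygen or the double bond is needed, which an amine in place of that oxygen, or a fully saturated chain, would test against compound 3.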